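The compounds below may be only part of what the source reports. "The series", "measured", "known", "first", "only" and "open" are said of these compounds alone.

Three hydroxamic acids built on one shared core have been measured in a physicochemical assay for solubility; a lower number here means a less soluble compound, a higher number a more soluble compound. Compound 1 `O=C(N[C@@H](CO)C(=O)NO)c1ccc(C#Cc2ccccc2)cc1` gives 28000 nM, compound 2 `NC(=O)C[C@H](NC(=O)c1ccc(C#Cc2ccccc2)cc1)C(=O)NO` gives 61000 nM, and compound 3 `CSC[C@H](NC(=O)c1ccc(C#Cc2ccccc2)cc1)C(=O)NO` gives 2000 nM, the lowest number of the three. The steps of a 14-fold lower number from compound 1 to compound 3 (1.15 log units; beyond the scatter) and a 31-fold lower number from compound 2 to compound 3 (1.48 log units; beyond the scatter) are both large. Compound 4 `CC(NC(=O)c1ccc(C#Cc2ccccc2)cc1)C(=O)NO` has not yet been measured; it differs from compound 3 in that (a group of 6 heavy atoms (3 carbon, 1 nitrogen, 2 oxygen; no ring) in place of a group of 8 heavy atoms (4 carbon, 1 nitrogen, 2 oxygen, 1 sulfur; no ring), on an amide-type nitrogen). The measured steps describe a methylsulfanyl group entering in place of hydroxy or carbamoyl, whereas here the methylsulfanyl-bearing group leaves altogether, so those steps bear on the change only indirectly. A modest rise in this assay is therefore expected, a 4.0-fold higher number from compound 3 to compound 4 (0.60 log units; beyond the scatter). Compound 4 is estimated at 8000 nM, within a range from 2000 nM to 35000 nM.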

Compound 4, solubility: 29000 nM
For compound 4 the middle estimate is 3.6-fold (0.56 log units) below the measured one; low and high end bracket the measured number.
By their numbers in this assay, from the lowest: compound 3; then compounds 1 and 4 (each within the scatter of the next); then compound 2.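

In this assay, 1-(hydroxycarbamoyl)ethyl in place of the methylsulfanyl-bearing group on the amide-type nitrogen gives a 15-fold higher number from compound 3 to compound 4 (1.16 log units; beyond the scatter), so this position needs neither hydroxy nor carbamoyl for a number well away from that of compound 3. In place of the hydroxy-bearing group, the same group gives a 1.0-fold higher number from compound 1 to compound 4 (0.02 log units; within the scatter), so hydroxy and its absence cannot be told apart here. No measured evidence accounts for either step. The compounds shown leave open where a longer chain without sulfur, an amine or a carboxylic acid at this position would stand. They also leave open whether the low number of compound 3 follows the sulfur itself or the length of its chain.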